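The source may report more compounds than this note shows. Statements on the series, on what has been measured and on what is new or still open speak of the compounds shown alone.

For the measured compounds named here, compound 1 `CCCn1c(=O)c2nc(-c3cnn(Cc4cc(C(F)(F)F)ccc4Cl)c3)[nH]c2n(CCC)c1=O` holds the lower of the two numbers measured so far in an in vitro assay on HEK293 cells for displacement of a labelled ligand from adenosine receptor A2b (Homo sapiens) (on this read-out lower numbers stand for stronger inhibition and higher numbers for weaker inhibition), where compound 1 gives 22 nM. Compound 2 `CCCn1c(=O)c2nc(-c3cc(C)nn3C)[nH]c2n(CCC)c1=O`, which carries a different substituent on the shared core, gives 3700 nM in this assay, and its value stands far above that of compound 1, well outside the usual scatter. Compound 3 `CCCn1c(=O)c2nc(-c3cnn(Cc4ccc(F)c(C(F)(F)F)c4)c3)[nH]c2n(CCC)c1=O` has not yet been measured in this assay. It differs from compound 1 in a single place: 4-fluoro-3-(trifluoromethyl)phenyl in place of 2-chloro-5-(trifluoromethyl)phenyl on a saturated chain carbon bound to an aromatic nitrogen. The core and the rest of the substituent are unchanged, so the comparison rests on this exchange within the aryl group alone. Going by the values given here, no measured pair in this set shows such an exchange, so the size of the step cannot be read from the numbers at hand; the only guide is that compound 1 sits at the strong end of what has been seen. In this assay the expected step is a 2.0-fold higher number from compound 1 to compound 3 (0.31 log units; beyond the scatter), a modest move toward a weaker number that may well stay within the scatter. Compound 3 is therefore estimated to give about 45 nM in this assay, with a range from 10 nM to 200 nM.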

Compound 3, inhibition constant: 640 nM
Compound 3: the middle estimate sits 14-fold (1.15 log units) below what was measured; the whole stated range lies below it.
By their numbers in this assay, from the lowest: compound 1; then compound 3; then compound 2.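

In this assay the exchange of 2-chloro-5-(trifluoromethyl)phenyl for 4-fluoro-3-(trifluoromethyl)phenyl on a saturated chain carbon bound to an aromatic nitrogen gives a 29-fold higher number from compound 1 to compound 3 (1.46 log units; beyond the scatter) and so counts as a large step. This shows that the number is sensitive to the substitution pattern of this aryl group, even though the group leaving and the group entering have the same count of heavy atoms, and neither has a hydrogen-bond donor or acceptor. Nothing at hand accounts for the size of this step.

The exchange alters two things at once, since the chlorine gives way to a fluorine and the numbering of the trifluoromethyl group shifts from 5 to 3, so compound 1 and compound 3 do not tell which of these carries the step. Also open, as far as these compounds go, is how the number would respond to a plain phenyl, to a phenyl bearing a single chlorine or a single trifluoromethyl group, or to a phenyl bearing a methoxy group or a nitrile.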